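Carbamate in place of glycinamide on the amine arm

The compounds below may be only part of what the source reports. "The series", "measured", "known", "first", "only" and "open" are said of these compounds alone.

Compound 1 `NC[C@@H]1CCCc2cc(S(=O)(=O)c3cccc(F)c3)ccc21`: 0.0794 nM
Compound 2 `COCCNC[C@@H]1CCCc2cc(S(=O)(=O)c3cccc(F)c3)ccc21`: 0.251 nM
Compound 3 `NCC(=O)NC[C@@H]1CCCc2cc(S(=O)(=O)c3cccc(F)c3)ccc21`: 0.316 nM

In an assay on isolated protein for displacement of a labelled ligand from 5-hydroxytryptamine receptor 6 (Homo sapiens) (on this read-out lower numbers stand for stronger inhibition and higher numbers for weaker inhibition), compound 3 gives the highest number of the three, though compound 2 sits within the scatter of it, as a 1.3-fold higher number from compound 2 to compound 3 (0.10 log units; within the scatter) shows; only compound 1 stands clearly apart, with a 4.0-fold higher number from compound 1 to compound 3 (0.60 log units; beyond the scatter). Compound 4 `COC(=O)NC[C@@H]1CCCc2cc(S(=O)(=O)c3cccc(F)c3)ccc21` differs from compound 3 by methoxy in place of aminomethyl on a carbonyl carbon. For the measured compounds named here, no measured step changes a group on that carbonyl carbon; the steps of a 3.2-fold higher number from compound 1 to compound 2 (0.50 log units; beyond the scatter) and a 4.0-fold higher number from compound 1 to compound 3 (0.60 log units; beyond the scatter) only show that dressing the amine nitrogen costs a modest amount. Compound 4 is therefore expected to stay near compound 3, with a step of a 1.3-fold higher number from compound 3 to compound 4 (0.10 log units; within the scatter) that may fall within the scatter. The estimate for compound 4 is 0.4 nM, between 0.13 nM and 1.3 nM.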

Compound 4, inhibition constant: 1.59 nM
Compound 4: middle estimate off by 4.0-fold (0.60 log units), on the low side; the measured number lies above the stated range.
By their numbers in this assay, from the lowest: compound 1; then compounds 2 and 3 (each within the scatter of the next); then compound 4.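

In this assay the group on the carbonyl carbon clearly matters: methoxy in place of aminomethyl gives a 5.0-fold higher number from compound 3 to compound 4 (0.70 log units; beyond the scatter) even though compound 2 and compound 3, with their different arms, lie within the scatter of each other. Methoxycarbonyl on the amine nitrogen also gives a 6.3-fold higher number from compound 2 to compound 4 (0.80 log units; beyond the scatter) against 2-methoxyethyl and a 20-fold higher number from compound 1 to compound 4 (1.30 log units; beyond the scatter) against hydrogen, the largest cost of changing that nitrogen among these compounds. Going by these compounds, whether a longer chain ending in an amine, or a carboxylic acid, on that carbonyl carbon would behave like aminomethyl or methoxy remains open. No supporting data explain the difference between aminomethyl and methoxy.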